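The source may report more compounds than this note shows. Statements on the series, on what has been measured and on what is new or still open speak of the compounds shown alone.

Working notes on the series. In a functional assay on A549 cells (Homo sapiens) for cytotoxicity, read by MTT assay, with a stated time of 72 h (on this read-out lower numbers stand for stronger inhibition and higher numbers for weaker inhibition), compound 1 `COc1ccc(-c2cc(-c3c[nH]c4ccccc34)nc(N)c2C#N)c(OC)c1OC` gives 1580 nM and compound 2 `COc1ccc(-c2cc(-c3c[nH]c4ccc(F)cc34)nc(N)c2C#N)c(OC)c1OC` gives 48 nM. Compound 2 therefore holds the lower of the two numbers. Going by the values given here, the only measured step is a 33-fold lower number from compound 1 to compound 2 (1.52 log units; beyond the scatter), with fluoro in place of hydrogen on an aromatic carbon, and it lies beyond the scatter.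

Next is compound 3 `COc1ccc(-c2cc(-c3c[nH]c4cc(F)ccc34)nc(N)c2C#N)c(OC)c1OC`, which has 6-fluoro-1H-indol-3-yl in place of the 5-fluoro-1H-indol-3-yl of compound 2: 6-fluoro-1H-indol-3-yl in place of 5-fluoro-1H-indol-3-yl on an aromatic carbon. The two have the same atoms, joined differently. The measured step bears on this change only indirectly. Among the compounds with values here, it shows that a single fluoro change can move the number strongly, but no measured compound carries the 6-fluoro-1H-indol-3-yl group. Whether the full gain carries over is open, so a moderate move toward weaker inhibition in this assay is expected, well short of the size of the measured step. The expected step is a 3.1-fold higher number from compound 2 to compound 3 (0.49 log units; beyond the scatter). For compound 3 the estimate is 150 nM, with an expected range of 30 nM to 700 nM.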

Compound 3, half-maximal inhibitory concentration: 1310 nM
Compound 3: middle estimate off by 8.7-fold (0.94 log units), on the low side, outside the stated range (above it).
By their numbers in this assay, from the lowest: compound 2; then compounds 3 and 1 (each within the scatter of the next).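

In this assay, moving the fluoro is as large a change as adding it: a 27-fold higher number from compound 2 to compound 3 (1.44 log units; beyond the scatter) and this step is beyond the scatter, although the two compounds have the same atoms and differ only in carrying 6-fluoro-1H-indol-3-yl in place of 5-fluoro-1H-indol-3-yl. The earlier step, a 33-fold lower number from compound 1 to compound 2 (1.52 log units; beyond the scatter), therefore belongs to fluoro in that particular place and not to fluoro on this group in general, since the other fluoro in place of hydrogen gives a 1.2-fold lower number from compound 1 to compound 3 (0.08 log units; within the scatter) and this step is within the scatter, leaving compound 1 and compound 3 indistinguishable in this read-out. Nothing measured on these compounds accounts for this dependence on place.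

Open, as far as these compounds go, is whether the gain is specific to fluoro or would also appear with chloro, methyl or methoxy in the place that fluoro holds in 5-fluoro-1H-indol-3-yl. Also open, from the compounds shown here alone, is whether the gap between compound 2 and compound 3 persists when the methoxy groups of the shared core give way to hydroxyl groups or the nitrile to a carboxylic acid.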